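The source may report more compounds than this note shows. Statements on the series, on what has been measured and on what is new or still open speak of the compounds shown alone.

Compound 1 `CCOC(=O)C1=Cc2ccccc2OC1(OCc1cn(-c2ccc(F)cc2)nn1)C(F)(F)F`: in a functional assay on DU-145 cells (Homo sapiens) for inhibition, read by MTT assay, with a stated time of 24 h (a higher number here means a weaker inhibitor, a lower number a stronger inhibitor), compound 1 gives 8900 nM.
Compound 2 `CCOC(=O)C1=Cc2ccccc2OC1(OCc1cn(-c2cccc(OC)c2)nn1)C(F)(F)F`: in this assay compound 2 gives > 150000 nM, a limit of the assay and not a number.
Compound 3 `CCOC(=O)C1=Cc2ccccc2OC1(OCc1cn(-c2cccc(C(F)(F)F)c2)nn1)C(F)(F)F`: in this assay compound 3 gives > 150000 nM, again a limit of the assay and not a number.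

Compound 3 therefore stands at the limit of > 150000 nM in this assay, at which 2 of the 3 values shown sit. Only compound 1 carries a number in this assay, and the two steps that start from it, an at least 16-fold higher number from compound 1 to compound 2 (1.22 log units; beyond the scatter) and an at least 16-fold higher number from compound 1 to compound 3 (1.22 log units; beyond the scatter), both run into that limit. The step that the two limits leave unreadable from compound 2 to compound 3 between the two limits cannot be read at all.

Compound 4 `CCOC(=O)C1=Cc2ccccc2OC1(OCc1cn(CC(=O)Nc2cccc(F)c2)nn1)C(F)(F)F` changes the group on the ring nitrogen in a different way: ((3-fluorophenyl)carbamoyl)methyl in place of 3-(trifluoromethyl)phenyl on an aromatic nitrogen. Within the data shown here, none of the measured steps exchanges an aryl group for a carbamoylmethyl group at this position, so none of them bears directly on the change; they only show that two of three aryl variants sit at the limit while compound 1 does not. The size and even the direction of the step from compound 3 to compound 4 are thus left open, and the estimated step of an at least 2.5-fold lower number from compound 3 to compound 4 (0.39 log units; beyond the scatter) carries wide uncertainty. Compound 4 is expected to give about 60000 nM in this assay, within a range from 8000 nM to 300000 nM.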

Compound 4, half-maximal inhibitory concentration: > 150000 nM
Compound 4: no number, only a limit (the forecaster's own chance of this, stated with the estimate: 45%); middle value at least 2.5-fold (0.39 log units) away from the limit.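

Among these compounds, the new group, ((3-fluorophenyl)carbamoyl)methyl, is the first on this aromatic nitrogen that is not an aryl group, and it brings a hydrogen-bond donor and a hydrogen-bond acceptor that the aryl groups lack, yet in this assay compound 4 also ends at a limit of the assay and not a number: the limit of > 150000 nM in this assay, at which 3 of the 4 values shown sit. Measured against the one numbered compound, the change gives an at least 16-fold higher number from compound 1 to compound 4 (1.22 log units; beyond the scatter), so 4-fluorophenyl remains the only group shown at this position that yields a number. On these data alone, the steps among compound 2, compound 3 and compound 4 join limit to limit and cannot be read, and the order of these three groups stays unknown.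

The compounds shown leave open whether ((4-fluorophenyl)carbamoyl)methyl on this nitrogen would give a number, which would tell whether the place of the fluorine on the carbamoylmethyl group's ring matters as well. They also leave open how a nitrogen substituent of another kind, such as a longer chain ending in an amine or a carboxylic acid, would read in this assay.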